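A Second Chloro on the Shared Purine-Like Core

A few compounds are considered here, and "the series" means these few. Any claim that something is new, unique, unknown or untested is made for them only; others in the source may bear on it.

Compound 1 `ClCc1cccc(Cn2cnc3ncnc(Cl)c32)c1` gives 8540 nM in a functional assay on NCI-H322M cells (Homo sapiens) for cytotoxicity, read by sulforhodamine B assay, with a stated time of 48 h; a lower number here means that less compound is tolerated, a higher number that more compound is tolerated. For the measured compounds named here, compound 2 `ClCc1cccc(Cn2cnc3c(Cl)ncnc32)c1`, which carries its single chloro group at another position of the same core, gives 6450 nM in this assay. Of the two numbers, compound 1 shows the higher one, yet the gap to compound 2 lies within the usual scatter of this kind of measurement, so the pair is best read as equivalent. Compound 3 `ClCc1cccc(Cn2cnc3nc(Cl)nc(Cl)c32)c1` has not yet been tested in this assay. It differs from compound 1 in one place: chloro in place of hydrogen on an aromatic carbon. The entering chloro sits on an aromatic carbon of a six-membered aromatic ring with 2 nitrogen, between two ring nitrogen atoms, meta to the chloro group already present. Going by the values given here, no measured pair shows what this change does, so the expected step of a 1.4-fold lower number from compound 1 to compound 3 (0.15 log units; within the scatter) is a small one that may not exceed the scatter. Compound 3 is estimated at 6000 nM, with a range from 2500 nM to 15000 nM.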

Compound 3, concentration lethal to 50% of the cells: 52500 nM
Compound 3: middle estimate off by 8.8-fold (0.94 log units), on the low side; measured number outside the range, above it.
By their numbers in this assay, from the lowest: compounds 2 and 1 (each within the scatter of the next); then compound 3.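

Chloro in place of hydrogen on an aromatic carbon, between two ring nitrogen atoms, is the first change in this series whose size can be read: in this assay it gives a 6.1-fold higher number from compound 1 to compound 3 (0.79 log units; beyond the scatter) and so counts as a modest step beyond the scatter. This position of the shared core therefore matters in this assay, and here the added chloro goes with more compound being tolerated, which compounds 1 and 2 alone could not show. Nothing available accounts for this step.

Going by these compounds, whether the step belongs to chloro itself or to any replacement of hydrogen at this position stays open, since an amine or a methyl group here would separate the two. Also open, on these data alone, is whether the same chloro would give a similar step on compound 2.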